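Ester variation on the furan-3-yl dihydropyrimidinone set

This account rests on a few compounds, and the source may have more. Where it says the series, first, only, none or still open, it means among the compounds named here.

Measured in an assay on membranes from CHO cells for displacement of a labelled ligand from adenosine receptor A1 (Homo sapiens), read by scintillation counting, with a stated time of 60 min, tested at 1 uM; a lower number here means less inhibition, a higher number more inhibition at the concentration tested (going by the name of the read-out):
compound 1 `CC1=C(C(=O)OCc2ccccc2)C(c2ccco2)NC(=O)N1`: 36%
compound 2 `CC1=C(C(=O)OCc2ccccc2)C(c2ccoc2)NC(=O)N1`: 41%
compound 3 `CC1=C(C(=O)OCc2ccccc2)C(c2ccoc2)NC(=O)N1C`: 51%

Compound 2 stands second highest of the three numbers in this assay. Its neighbours sit close: a number 5 percentage points higher from compound 1 to compound 2 (within the scatter) and a number 10 percentage points higher from compound 2 to compound 3 (within the scatter), both steps within the scatter. Compound 4 `CC1=C(C(=O)OCC2CC2)C(c2ccoc2)NC(=O)N1` is drawn from compound 2 by cyclopropyl in place of phenyl on a saturated chain carbon bound to an oxygen next to a carbonyl group. Among the measured compounds shown here, neither measured step touches the ester side of the core; one moves the furan attachment, the other adds a methyl on the ring nitrogen, so there is no measured step that bears on this change. For compound 4 a modest downward step is expected, a number 11 percentage points lower from compound 2 to compound 4 (beyond the scatter), with wide uncertainty. Compound 4 is thus estimated at 30%, within a range of 10% to 55%.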

Compound 4, a percentage reported as inhibition, at one concentration (the size of the read-out at that concentration, not a potency): 29%
Compound 4: middle estimate off by 1 percentage points, on the high side, within the range that was stated.
By their numbers in this assay, from the lowest: compounds 4, 1, 2 and 3 (each within the scatter of the next, the first and the last beyond it).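

Among the compounds shown here, the ester side of the core now has a measured step: cyclopropyl in place of phenyl gives a number 12 percentage points lower from compound 2 to compound 4 (beyond the scatter) in this assay and is the only step in the set beyond the scatter. Compound 4 still reads 29% without the phenyl ring, so an aromatic ring at this place is not required for some inhibition at the concentration tested. Nothing available explains the step.

The change alters both ring type and heavy-atom count, and a cyclohexylmethyl ester would help separate the two. Also open, on these data alone, is whether the ring-nitrogen methyl of compound 3 behaves the same way alongside a cyclopropylmethyl ester.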